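The source may report more compounds than this note shows. Statements on the series, on what has been measured and on what is new or still open speak of the compounds shown alone.

Measured so far in a functional assay for antagonist activity at corticotropin-releasing factor receptor 1 (Rattus norvegicus); on this read-out higher numbers stand for weaker inhibition and lower numbers for stronger inhibition:
compound 1, `CCC(C1CC1)n1c(=O)c(C)nc2c(-c3cc(C)c(C)cc3C)ccnc21`: 5.2 nM
compound 2, `CCCC(C)n1c(=O)c(C)nc2c(-c3ccc(Cl)cc3Cl)ccnc21`: 62 nM
compound 3, `CC[C@@H](C1CC1)n1c(=O)c(C)nc2c(-c3ccc(Cl)cc3Cl)nccc21`: 55 nM

Compound 1 stands at the lowest number of the three in this assay. Compound 3 is its nearest neighbour and compound 2 the furthest, and both gaps lie beyond the scatter, so compound 1 is the strongest inhibitor of the set as it stands. Compound 2 and compound 3 lie within the scatter of each other and are not ordered. Going by the values given here, no pair of measured compounds differs in a single place, so no measured step size is available for any change on its own.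

Compound 4, `CCC(C1CC1)n1c(=O)c(C)nc2c(-c3ccc(C)cc3C)ccnc21`, differs from compound 1 in one place: hydrogen in place of methyl on an aromatic carbon. Cut one bond further out, the same difference reads 2,4,5-trimethylphenyl to 2,4-dimethylphenyl.

The measured set gives no direct guide to this change, as compound 2 and compound 3 differ from compound 1 in the aryl group and elsewhere at once. A modest step toward a higher number, probably just beyond the scatter, is expected from compound 1 to compound 4, a 2.9-fold higher number from compound 1 to compound 4 (0.46 log units; beyond the scatter). Compound 4 is therefore estimated at 15 nM in this assay, with a range from 5 nM to 45 nM.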

Compound 4, half-maximal inhibitory concentration: 8.8 nM
Beside the measured number, compound 4's estimate is 1.7-fold (0.23 log units) above it; the measured number falls inside the stated range.
By their numbers in this assay, from the lowest: compounds 1 and 4 (each within the scatter of the next); then compounds 3 and 2 (each within the scatter of the next).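

In this assay, going by these compounds alone, the change from 2,4,5-trimethylphenyl to 2,4-dimethylphenyl gives a 1.7-fold higher number from compound 1 to compound 4 (0.23 log units; within the scatter) and is the first single-place step available. On this evidence, the aromatic carbon ortho to a methyl group, meta to a large group and para to a methyl group can carry either methyl or hydrogen without a change that can be read apart from the scatter, so the extra methyl of compound 1 is not shown to matter for this read-out. No measurement on hand offers an explanation for this result.

Going by these compounds, whether this position accepts more than hydrogen or methyl remains open: a methoxy group, an ethyl group or an amine on the same aromatic carbon would test whether the number stays put when the substituent changes in size or kind. Steps from compound 1 or compound 4 to compound 2 and compound 3 cannot be read because these pairs differ in more than one place, which leaves the separate roles of the aryl group, the chain and the core unresolved.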